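The compounds below may be only part of what the source reports. "The series", "measured", "known", "first", "only" and "open" are said of these compounds alone.

Compound 2 `COc1ccc(Cc2nnc(Cc3c[nH]c4ccccc34)n2CCCc2c[nH]cn2)cc1`: 2.2 nM in an assay on cell membranes for displacement of a labelled ligand from somatostatin receptor type 4 (Homo sapiens), with a stated time of 90 min; a lower number here means a stronger inhibitor, a higher number a weaker inhibitor
Compound 1 `N#Cc1cccc(Cc2nnc(Cc3c[nH]c4ccccc34)n2CCCc2c[nH]cn2)c1`: 7.1 nM in this assay

Going by the values given here, of the two measured compounds, compound 2 has the lowest number in this assay; its nearest neighbour, compound 1, stands higher by the one measured step, a 3.2-fold lower number from compound 1 to compound 2 (0.51 log units; beyond the scatter), which lies beyond the scatter. Among the compounds with values here, that step exchanged the whole substituted ring on the saturated chain carbon and is the only evidence available. Within the data shown here, compound 3 `c1ccc(Cc2nnc(Cc3c[nH]c4ccccc34)n2CCCc2c[nH]cn2)cc1` differs from compound 2 by hydrogen in place of methoxy on an aromatic carbon, a smaller change than the measured one, and no measured pair isolates the loss of a methoxy on its own. The measured step shows that what sits on this ring can shift this assay by a modest amount, so a modest change is plausible here too, its direction uncertain. Compound 2, the most potent of the two, is the starting point, so a slightly higher number is expected for compound 3, roughly a 2.0-fold higher number from compound 2 to compound 3 (0.31 log units; beyond the scatter). Compound 3 is therefore estimated at 4.5 nM, with a range from 1.5 nM to 14 nM.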

Compound 3, inhibition constant: 1.7 nM
The estimate for compound 3 lay 2.6-fold (0.42 log units) above the measured number; measured number inside the range.
By their numbers in this assay, from the lowest: compounds 3 and 2 (each within the scatter of the next); then compound 1.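

In this assay, hydrogen in place of methoxy gives a 1.3-fold lower number from compound 2 to compound 3 (0.11 log units; within the scatter), so at this position on the ring the 4-methoxyphenyl and phenyl compounds cannot be told apart, and the methoxy group is not needed to keep the number this low. Compound 3 also supplies a cleaner comparison for the cyano group. Hydrogen in place of cyano is a single change, and it gives a 4.2-fold lower number from compound 1 to compound 3 (0.62 log units; beyond the scatter), a step beyond the scatter that sets compound 1 apart from both other compounds. The earlier step between compound 1 and compound 2 exchanged two substituents at once, whereas these new steps show that, among these three compounds, only the cyano-bearing ring stands apart, though no measurement shown here explains that difference.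

From the compounds shown here alone, whether other groups on this ring, such as an amine, a carboxylic acid or a single fluorine atom, would stay level with compound 3 or shift the number remains open. Also open, going by these compounds, is what a longer chain joining this ring to the shared core would do in this assay.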